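This account rests on a few compounds, and the source may have more. Where it says the series, first, only, none or still open, it means among the compounds named here.

Three urea analogues built on one shared core have been examined in a functional assay on MGC-803 cells (Homo sapiens) for antiproliferative activity, read by MTT assay, with a stated time of 48 h; on this read-out lower numbers stand for stronger inhibition and higher numbers for weaker inhibition. Compound 1 `Cc1ccc(NC(=O)Nc2cccc(CNc3nccnc3Cl)c2)c(C)c1` gives 10100 nM in this assay. Compound 2 `CC(C)(C)c1ccc(NC(=O)Nc2cccc(CNc3nccnc3Cl)c2)cc1` gives 4820 nM in this assay, and compound 3 `CCc1ccc(NC(=O)Nc2cccc(CNc3nccnc3Cl)c2)c(CC)c1` gives 6130 nM in this assay. Among these three numbers compound 1 stands highest; its gap to compound 3 lies within the usual scatter, whereas its gap to compound 2 lies beyond it, so compound 2 shows stronger inhibition than compound 1.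

Compound 4 `O=C(Nc1cccc(CNc2nccnc2Cl)c1)Nc1ccc(Cl)c(Cl)c1` has not yet been measured in this assay. It differs from compound 1 in a single place: 3,4-dichlorophenyl in place of 2,4-dimethylphenyl on an amide-type nitrogen. For the measured compounds named here, no measured pair among the three compounds carries this change, so there is no measured step to lean on; the three values only show that exchanging the group on the amide-type nitrogen has so far moved the number by a small amount. A modest step toward a lower number, that is toward stronger inhibition, is expected, and the expected step is a 2.5-fold lower number from compound 1 to compound 4 (0.40 log units; beyond the scatter), though a step no larger than the scatter would not surprise. Compound 4 is expected to give about 4000 nM in this assay, with a range from 1500 nM to 12000 nM.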

Compound 4, half-maximal inhibitory concentration: 4970 nM
The estimate for compound 4 lay 1.2-fold (0.09 log units) below the measured number, within the range that was stated.
By their numbers in this assay, from the lowest: compounds 2, 4, 3 and 1 (each within the scatter of the next, the first and the last beyond it).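

In this assay, for the compounds shown here, the exchange of 2,4-dimethylphenyl for 3,4-dichlorophenyl on an amide-type nitrogen gives a 2.0-fold lower number from compound 1 to compound 4 (0.31 log units; beyond the scatter) and so provides the first measured step at this position, a modest one that lies beyond the usual scatter. The two groups have the same count of heavy atoms, the same single six-membered aromatic ring of carbon only, no hydrogen-bond donors or acceptors and no net charge, so a change in the number is seen here even though these counts stay the same. No measurement shown accounts for the step.

The compounds shown leave open whether the step follows the replacement of methyl by chlorine or the shift in substitution from the pattern of 2,4-dimethylphenyl to that of 3,4-dichlorophenyl, a question that 3,4-dimethylphenyl on the same nitrogen would help to separate. They also leave open how the number would respond to a group of a different kind at this position, such as a phenyl ring carrying an amine or a carboxylic acid.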